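Swapping the furan for a pyridine on the shared core

This account rests on a few compounds, and the source may have more. Where it says the series, first, only, none or still open, it means among the compounds named here.

Compound 2 `Oc1cccc(-c2cc(-c3ccco3)cc(-c3cccc(O)c3)n2)c1` is one of three measured members of a series built on a common core. In a functional assay on DU-145 cells (Homo sapiens) for cytotoxicity, read by CCK-8 assay (a lower number here means a stronger inhibitor, a higher number a weaker inhibitor), compound 2 gives 2150 nM. Compound 1 `Oc1cccc(-c2cc(-c3ccco3)cc(-c3ccccc3O)n2)c1` gives 1790 nM in this assay, and compound 3 `Oc1ccc(-c2cc(-c3ccco3)cc(-c3cccc(O)c3)n2)cc1` gives 2070 nM. All three lie in a narrow band: the steps of a 1.2-fold higher number from compound 1 to compound 2 (0.08 log units; within the scatter), a 1.2-fold higher number from compound 1 to compound 3 (0.06 log units; within the scatter) and a 1.0-fold lower number from compound 2 to compound 3 (0.02 log units; within the scatter) are each within the scatter, so compound 2 cannot be set apart from the other two.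

Compound 4 `Oc1cccc(-c2cc(-c3cccnc3)cc(-c3cccc(O)c3)n2)c1` has not yet been measured in this assay. It differs from compound 2 in one place: pyridin-3-yl in place of furan-2-yl on an aromatic carbon. For the measured compounds named here, none of the measured steps touches this position; the three steps seen so far move only the hydroxyl on one of the hydroxyphenyl groups, and each stays within the scatter. From the compounds shown here alone, nothing measured therefore speaks for a step in either direction from compound 2 to compound 4, and the change itself is untested.

Compound 4 is consequently expected to land close to compound 2, with a step of a 1.1-fold higher number from compound 2 to compound 4 (0.05 log units; within the scatter) in this assay, and its estimated value is 2400 nM, with a range from 800 nM to 7500 nM.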

Compound 4, half-maximal inhibitory concentration: > 50000 nM
Compound 4 gave a limit, no number (the forecaster's own chance of this, stated with the estimate: 5%); at least 20-fold (1.31 log units) between middle value and limit.
By their numbers in this assay, from the lowest: compounds 1, 3 and 2 (each within the scatter of the next). At a limit, above all of these: compound 4.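

For the compounds shown here, the position opposite the ring nitrogen of the shared core, which no earlier step touched, proves far more sensitive than the placement of the hydroxyl on the hydroxyphenyl groups. In this assay, pyridin-3-yl in place of furan-2-yl gives an at least 23-fold higher number from compound 2 to compound 4 (1.36 log units; beyond the scatter), whereas each move of the hydroxyl stayed within the scatter. Compound 4 reads > 50000 nM, which is a limit and not a number, so the step gives only a minimum size and the true value of compound 4 stays unknown: the limit of > 50000 nM in this assay, at which 1 of the 4 values shown sits.

This single replacement changes a five-membered aromatic ring to a six-membered one and an oxygen to a nitrogen at the same time, so the compounds shown cannot separate the effect of ring size from that of the hetero atom. Also open, from the compounds shown here alone, is whether a thiophene, a plain phenyl ring or a pyridin-2-yl group at this carbon would stay near compound 2 or fall away as compound 4 does, and whether the same replacement would have the same result with the hydroxyl placed as in compound 1 or compound 3.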